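The source may hold more compounds than are shown below. What is called first, only, known or untested is meant among the compounds shown, and "the series" means these compounds.

Measured compounds in a functional assay on HCT-116 cells (Homo sapiens) for antiproliferative activity, with a stated time of 48 h; a higher number here means a weaker inhibitor, a lower number a stronger inhibitor:
compound 1, `CCN(CC)c1ccc(-c2cccc(C(F)(F)F)c2)nn1`: > 25000 nM
compound 2, `CCN(CC)c1ccc(-c2ccc(C#N)cc2)nn1`: > 25000 nM

In this assay compound 1 gives only a limit of the assay, > 25000 nM, not a number. Compound 2 likewise gives only a limit in this assay, > 25000 nM. Among the compounds with values here, the whole series so far rests at the limit of > 25000 nM in this assay, at which 2 of the 2 values shown sit, so no step between measured compounds can be read: the two values show only that neither compound has antiproliferative activity that this assay can put a number on.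

Compound 3, `CCN(CC)c1ccc(-c2ccc(C(=O)O)cc2)nn1`, has not yet been measured in this assay. It differs from compound 2 in one place, (carboxy in place of cyano on an aromatic carbon).

Within the data shown here, no measured step exists to give the size of such a change on this core. With compound 2 at a limit, no movement beyond the scatter is expected in either direction; the most likely outcome is a further limit. Among the measured compounds shown here, the expected step is a step that the limit leaves unreadable from compound 2 to compound 3, a guess resting on no measured step. Compound 3 is estimated at 40000 nM in this assay, within a range of 15000 nM to 150000 nM, and most likely reported only as a limit.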

Compound 3, half-maximal inhibitory concentration: > 25000 nM
Compound 3 ended at the assay's limit (the forecaster's own chance of this, stated with the estimate: 85%); the middle value does not contradict the limit.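

In this assay compound 3 gives > 25000 nM, a limit of the assay and not a number. Within the data shown here, compound 2 also gives only a limit, so no step from compound 2 to compound 3 can be read: the limit of > 25000 nM in this assay, at which 3 of the 3 values shown sit. The compounds shown leave open whether any change on the shared core gives antiproliferative activity that this assay can put a number on.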